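From thiophene carboxamide to 1,2-oxazole: expected solubility

The source may report more compounds than this note shows. Statements on the series, on what has been measured and on what is new or still open speak of the compounds shown alone.

Compound 1, `CC(C)CN1C(=O)c2ccccc2[C@H](C(=O)Nc2ccc(F)c(C#N)c2)[C@H]1c1ccsc1`: in a physicochemical assay for solubility, in phosphate buffer, with a stated time of 18 h, at pH 7 (a higher number here means a more soluble compound, a lower number a less soluble compound), compound 1 gives < 1000 nM, which is a limit of the assay.
Compound 2, `CC(C)CN1C(=O)c2ccccc2[C@H](C(=O)Nc2ccc(F)c(C#N)c2)[C@H]1c1ccc(C#N)s1`: compound 2 gives 4900 nM.
Compound 3, `CC(C)CN1C(=O)c2ccccc2[C@H](C(=O)Nc2ccc(F)c(C#N)c2)[C@H]1c1ccc(C(N)=O)s1`: compound 3 gives 19000 nM.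

Compound 3 stands highest of the two numbers that are actual values; the nearest is compound 2, and the step between them was a 3.9-fold higher number from compound 2 to compound 3 (0.59 log units; beyond the scatter). Compound 1 sits at a limit, (the limit of < 1000 nM in this assay, at which 1 of the 3 values shown sits), so the steps from it are only bounds: an at least 4.9-fold higher number from compound 1 to compound 2 (0.69 log units; beyond the scatter) and an at least 19-fold higher number from compound 1 to compound 3 (1.27 log units; beyond the scatter).

Compound 4, `CC(C)CN1C(=O)c2ccccc2[C@H](C(=O)Nc2ccc(F)c(C#N)c2)[C@H]1c1ccno1`, has not yet been measured. Its change from compound 3 is 1,2-oxazol-5-yl in place of 5-carbamoylthiophen-2-yl on a saturated ring carbon. All three measured steps bear on it, since each exchanges the group on the same saturated ring carbon, and together they span an at least large range between the plain thiophen-3-yl of compound 1 and the carbamoyl-bearing ring of compound 3. The 1,2-oxazol-5-yl ring carries no hydrogen-bond donor, unlike the group it replaces, and so a lower number than compound 3 is expected, of a modest to large size: a 4.8-fold lower number from compound 3 to compound 4 (0.68 log units; beyond the scatter). Compound 4 is estimated at 4000 nM, within 1000 nM to 15000 nM.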

Compound 4, solubility: 53000 nM
Beside the measured number, compound 4's estimate is 13-fold (1.12 log units) below it; measured number above the stated range.
By their numbers in this assay, from the lowest: compound 2; then compound 3; then compound 4. At a limit, below all of these: compound 1.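

Until now the highest number at this saturated ring carbon belonged to the carbamoyl-bearing thiophene, but in this assay the 1,2-oxazol-5-yl group, which has no hydrogen-bond donor and no sulfur, goes past it, with a 2.8-fold higher number from compound 3 to compound 4 (0.45 log units; beyond the scatter). Against the nitrile-bearing thiophene the rise is wider, with an 11-fold higher number from compound 2 to compound 4 (1.03 log units; beyond the scatter), so among the groups shown a hydrogen-bond donor at this carbon is not required for the highest number. Compound 1 stands at a limit, so the step to the 1,2-oxazol-5-yl group is only a bound, an at least 53-fold higher number from compound 1 to compound 4 (1.72 log units; beyond the scatter), and its true size stays unknown: the limit of < 1000 nM in this assay, at which 1 of the 4 values shown sits.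

With a single ring of this kind among them, the compounds shown do not separate the effect of the ring's hetero atoms from that of its smaller size. Nor do they tell how a 1,2-oxazol-5-yl ring carrying a carbamoyl group, an amine or a carboxylic acid would read in this assay.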